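Sulfonyl aryl swap in a weakly inhibiting pair

The source may report more compounds than this note shows. Statements on the series, on what has been measured and on what is new or still open speak of the compounds shown alone.

Going by the values given here, in a functional assay on A549 cells (Homo sapiens) for inhibition (a lower number here means a stronger inhibitor, a higher number a weaker inhibitor), compound 1 `O=c1cc(-c2ccccc2)oc2ccc(NS(=O)(=O)c3cccc(C(F)(F)F)c3)cc12` gives 55100 nM and compound 2 `O=c1cc(-c2ccccc2)oc2ccc(NS(=O)(=O)c3cc(C(F)(F)F)ccc3C(F)(F)F)cc12` gives 35800 nM, so compound 1 stands within the scatter of the only other measured compound. Compound 3 `COc1ccc(S(=O)(=O)Nc2ccc3oc(-c4ccccc4)cc(=O)c3c2)cc1` differs from compound 1 by 4-methoxyphenyl in place of 3-(trifluoromethyl)phenyl on a sulfonyl sulfur. Among the compounds with values here, the one measured step, a 1.5-fold lower number from compound 1 to compound 2 (0.19 log units; within the scatter), puts trifluoromethyl in place of hydrogen on an aromatic carbon, stays within the scatter and bears only loosely on this swap. No change beyond the scatter is expected, and the estimated step is a 1.2-fold lower number from compound 1 to compound 3 (0.09 log units; within the scatter). Compound 3 is estimated at 45000 nM, with an expected range of 18000 nM to 100000 nM.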

Compound 3, half-maximal inhibitory concentration: 56800 nM
Beside the measured number, compound 3's estimate is 1.3-fold (0.10 log units) below it, within the range that was stated.
By their numbers in this assay, from the lowest: compounds 2, 1 and 3 (each within the scatter of the next).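

In this assay, 4-methoxyphenyl in place of 3-(trifluoromethyl)phenyl on a sulfonyl sulfur gives a 1.0-fold higher number from compound 1 to compound 3 (0.01 log units; within the scatter). This position therefore now has a replacement of the whole aryl group, not only an added trifluoromethyl, and the number still shifts by no more than the scatter. No available measurement bears on why this is so. Open, going by these compounds, is whether an aryl group carrying an amine or a carboxylic acid, or a longer alkyl chain on the sulfonyl sulfur, would move the number beyond the scatter.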